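Cyano in Place of Trifluoromethyl on a Sulfonamide Core

The source may hold more compounds than are shown below. What is called first, only, known or untested is meant among the compounds shown, and "the series" means these compounds.

Compound 1, `CN(C)CC[C@H](CSc1ccccc1)Nc1ccc(S(=O)(=O)NC(=O)c2ccc(N3CCN(Cc4ccccc4-c4ccc(Cl)cc4)CC3)cc2)cc1C(F)(F)F`, was measured in an assay on isolated protein for displacement of a labelled ligand from Bcl2-associated agonist of cell death (Homo sapiens), read by fluorescence polarization; on this read-out lower numbers stand for stronger inhibition and higher numbers for weaker inhibition. In this assay compound 1 gives < 1 nM, which is a limit of the assay and not a number. Compound 2, `CN(C)CC[C@H](CSc1ccccc1)Nc1ccc(S(=O)(=O)NC(=O)c2ccc(N3CCN(CC4=C(c5ccc(Cl)cc5)CCCC4)CC3)cc2)cc1[N+](=O)[O-]`, differs from compound 1 in more than one place, and in this assay compound 2 also gives < 1 nM, again a limit rather than a number. Where compound 1 stands can therefore be said only loosely: both values sit at the limit of < 1 nM in this assay, at which 2 of the 2 values shown sit, and no step between measured compounds with a single difference is available. Compound 3, `CN(C)CC[C@H](CSc1ccccc1)Nc1ccc(S(=O)(=O)NC(=O)c2ccc(N3CCN(Cc4ccccc4-c4ccc(Cl)cc4)CC3)cc2)cc1C#N`, has not yet been measured. The change from compound 1 to compound 3 is cyano in place of trifluoromethyl on an aromatic carbon. For the measured compounds named here, no measured step gives a size for this exchange, so the expectation rests on the shared core alone. Because compound 1 sits at the limit of < 1 nM in this assay, at which 2 of the 2 values shown sit, the step expected for this assay is small, a number no lower from compound 1 to compound 3 (the limit leaves the size open), lying within the scatter or amounting to a modest weakening. Compound 3 is accordingly estimated at 1 nM, with a range from 0.3 nM to 5 nM.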

Compound 3, inhibition constant: < 1 nM
Compound 3 ended at the assay's limit (the forecaster's own chance of this, stated with the estimate: 50%); the middle value sits exactly at the limit.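

In this assay, for the compounds shown here, compound 1 and compound 3 both end at a limit of the assay and not at a number, so no step between them can be read: the limit of < 1 nM in this assay, at which 3 of the 3 values shown sit. The compounds shown leave open whether cyano in place of trifluoromethyl on an aromatic carbon changes the inhibition constant at all, and by how much.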